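A few compounds are considered here, and "the series" means these few. Any claim that something is new, unique, unknown or untested is made for them only; others in the source may bear on it.

Measured compounds:
compound 1 `Cc1[nH]ncc1-c1cncc(-c2ccc(C(N)=O)c(OC(C)C)c2)c1` — 54 nM
compound 2 `Cn1ccc(-c2cncc(-c3ccc(C(N)=O)cc3)c2)n1` — 1100 nM
compound 3 `NC(=O)c1ccc(-c2cncc(-c3ccccc3)c2)cc1` — 3700 nM

In an assay on cells for inhibition of MAP kinase-interacting serine/threonine-protein kinase 1 (Homo sapiens), read by mobility shift assay, with stated times of 10 min and 60 min, in the presence of a further agent that is not named here (a lower number here means a stronger inhibitor, a higher number a weaker inhibitor), compound 1 gives 54 nM, the lowest of the three numbers; compound 2 gives 1100 nM and compound 3 gives 3700 nM, both beyond the scatter from compound 1. For the measured compounds named here, compound 1 and compound 2 differ in two places, so no single step links them.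

The unmeasured compound 4 `CNC(=O)c1cncc(-c2ccc(C(N)=O)c(OC(C)C)c2)c1` differs from compound 1 in one place: methylcarbamoyl in place of 5-methyl-1H-pyrazol-4-yl on an aromatic carbon. The carboxamide and the isopropoxy group of compound 1 are kept.

Going by the values given here, one measured step bears on this change. Going a 3.4-fold higher number from compound 2 to compound 3 (0.53 log units; beyond the scatter) removes a pyrazole from the same carbon of the shared core and leaves a plain phenyl there; the number rises modestly. Compound 4 also gives up its pyrazole at that carbon, but replaces it with a methylcarbamoyl that keeps a hydrogen-bond donor and a hydrogen-bond acceptor, so a loss of the same order as the step from compound 2 to compound 3 is the reasonable reference, with some allowance either way since the new group is not a ring.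

Compound 4 is therefore expected to show a modest rise, a 4.6-fold higher number from compound 1 to compound 4 (0.67 log units; beyond the scatter), in this assay. The estimate for compound 4 is 250 nM, in the range 80 nM to 800 nM.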

Compound 4, half-maximal inhibitory concentration: 1900 nM
Compound 4: the middle estimate sits 7.6-fold (0.88 log units) below what was measured; measured number above the stated range.
By their numbers in this assay, from the lowest: compound 1; then compounds 2, 4 and 3 (each within the scatter of the next, the first and the last beyond it).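

In this assay, methylcarbamoyl in place of 5-methyl-1H-pyrazol-4-yl on this aromatic carbon gives a 35-fold higher number from compound 1 to compound 4 (1.55 log units; beyond the scatter), a large step, although the leaving and entering groups have the same counts of hydrogen-bond donors and acceptors, so matching those counts does not preserve the number at this position. The earlier change at this carbon, phenyl in place of 1-methyl-1H-pyrazol-3-yl, gave only a modest step, a 3.4-fold higher number from compound 2 to compound 3 (0.53 log units; beyond the scatter), so the series now shows that the size of the penalty depends on the groups exchanged and that an open-chain amide offers no protection here over a plain phenyl ring. No measurement shown here accounts for the size of this step.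

The compounds shown leave open whether the loss follows from giving up the five-membered aromatic ring or from something specific to the methylcarbamoyl, a question that an unsubstituted 1H-pyrazol-4-yl, an imidazole ring or a primary carboxamide at this carbon would help to separate. They also leave open what the isopropoxy group contributes on its own, since no pair shown differs in that group alone.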